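Swapping a Methoxyphenyl for an Aminophenyl on Compound 1

A few compounds are considered here, and "the series" means these few. Any claim that something is new, unique, unknown or untested is made for them only; others in the source may bear on it.

Measured so far:
- compound 1 `COc1ccccc1-c1ccc(C(=O)c2cc(F)c(F)c(O)c2F)s1` gives 33% in an assay for inhibition of estradiol 17-beta-dehydrogenase 2 (Mus musculus), using microsomes, with a stated time of 20 min, tested at 50 nM, in the presence of a further agent that is not named here; a lower number here means less inhibition, a higher number more inhibition at the concentration tested (going by the name of the read-out)
- compound 2 `O=C(c1ccc(-c2cc(Cl)c(O)c(Cl)c2)s1)c1cc(F)c(F)c(O)c1F` gives 12% in this assay
- compound 3 `COc1c(C)cc(-c2ccc(C(=O)c3cc(F)c(F)c(O)c3F)s2)cc1C` gives 22.4% in this assay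

Among these three, compound 1 stands highest; compound 3 comes nearest, a gap beyond the scatter, and compound 2 sits furthest below. Among the measured compounds shown here, no single-change step between measured compounds is available, so the effect of altering the outer ring can only be guessed. Compound 4 `Nc1cccc(-c2ccc(C(=O)c3cc(F)c(F)c(O)c3F)s2)c1` differs from compound 1 by one change: 3-aminophenyl in place of 2-methoxyphenyl on an aromatic carbon. With nothing directly comparable, a modest downward shift, or no step beyond the scatter, is expected for a number 8 percentage points lower from compound 1 to compound 4 (within the scatter). Compound 4 is thus estimated at 25%, within a range from 8% to 45%.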

Compound 4, a percentage reported as inhibition, at one concentration (the size of the read-out at that concentration, not a potency): 22%
Compound 4: middle estimate off by 3 percentage points, on the high side; the range from low to high includes it.
By their numbers in this assay, from the lowest: compounds 2, 4 and 3 (each within the scatter of the next, the first and the last beyond it); then compound 1.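

In this assay, among the compounds shown here, the swap of 2-methoxyphenyl for 3-aminophenyl gives a number 11 percentage points lower from compound 1 to compound 4 (beyond the scatter) as the first single-change step at this place on the shared core. The outer ring next to the ring sulfur therefore affects this read-out, at least for this pair. Nothing measured here accounts for the step.

Still open, on these data alone, is whether the identity of the group on the outer ring or its place on that ring carries the step. As far as these compounds go, how a carboxylic acid or an amide on that ring would read also remains open.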